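Butyl in place of the ring group

A few compounds are considered here, and "the series" means these few. Any claim that something is new, unique, unknown or untested is made for them only; others in the source may bear on it.

In a functional assay with Mus musculus as the target (a lower number here means that less compound is needed, a higher number that more compound is needed for the effect), compound 1 (`C=CCn1c(=O)n([C@H]2CO[C@@H](CO)C2)c2nc(N)nc(O)c21`) gives 272 uM, the middle of three numbers. Compound 3 (`CCOC(=O)Cn1c(=O)n(C2OC(CO)[C@@H](O)[C@H]2O)c2nc(N)nc(O)c21`) gives 630 uM, and compound 2 (`COc1ccc(Cn2c(=O)n(C3OC(CO)[C@@H](O)[C@H]3O)c3nc(N)nc(O)c32)cc1`) gives 2 uM. Compound 4 (`C=CCn1c(=O)n(CCCC)c2nc(N)nc(O)c21`) differs from compound 1 by a group of 4 heavy atoms (4 carbon; no ring) in place of a group of 7 heavy atoms (5 carbon, 2 oxygen; one five-membered non-aromatic ring with 1 hetero atom), on an aromatic nitrogen: butyl replaces the ring group. Within the data shown here, the only measured step is a 320-fold higher number from compound 2 to compound 3 (2.50 log units; beyond the scatter), a large one with ethoxycarbonyl in place of 4-methoxyphenyl on a saturated chain carbon. Among the measured compounds shown here, it does not touch the group leaving here, so it shows only that one change moved the number far, and it gives no direction for this change. The working expectation is no shift beyond the scatter, with an estimated 1.4-fold lower number from compound 1 to compound 4 (0.13 log units; within the scatter) and wide uncertainty. Compound 4 is estimated at 200 uM, with an expected range of 30 uM to 1000 uM.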

Compound 4, concentration for half-maximal effect: 11 uM
For compound 4 the middle estimate is 18-fold (1.26 log units) above the measured one; measured number outside the range, below it.
By their numbers in this assay, from the lowest: compound 2; then compound 4; then compound 1; then compound 3.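

In this assay, butyl in place of the ring group on the aromatic nitrogen gives a 25-fold lower number from compound 1 to compound 4 (1.39 log units; beyond the scatter), so the number at this position responds strongly to the group it carries. A group with no ring, no hydrogen-bond donor and no defined stereocentre is compatible with this lower number. Nothing at hand gives a cause for this step.

Going by these compounds, whether the step follows the loss of the ring, its oxygens or its stereocentres stays open. A cyclopentyl group or a hexyl chain on this nitrogen would help separate these.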